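The source may hold more compounds than are shown below. What is called first, only, known or untested is meant among the compounds shown, and "the series" means these compounds.

In a functional assay on HepG2 cells (Homo sapiens) for inhibition, read by MTT assay, with a stated time of 72 h (a lower number here means a stronger inhibitor, a higher number a weaker inhibitor), the measured compounds are:
compound 1 `O=C1/C(=C\c2ccccc2)c2c(ncn2COCc2ccccc2)CCN1Cc1ccc(F)cc1` 39400 nM
compound 2 `O=C1/C(=C\c2ccccc2)c2c(ncn2COCc2ccccc2)CCN1Cc1ccc(-c2ccccc2)cc1` 72500 nM
compound 3 `COc1cc(/C=C2\C(=O)N(Cc3ccccc3)CCc3ncn(COCc4ccccc4)c32)cc(OC)c1OC` 10000 nM

Compound 2 gives 72500 nM and stands level with compound 1 within the scatter, while compound 3 shows a lower number at 10000 nM in the same read-out. Compound 4 `O=C1/C(=C\c2ccccc2)c2c(ncn2COCc2ccccc2)CCN1Cc1ccc2ccccc2c1` carries naphthalen-2-yl in place of 4-phenylphenyl on a saturated chain carbon bound to an amide-type nitrogen in a ring. Within the data shown here, one measured step bears on this change, phenyl in place of fluoro on an aromatic carbon, with the result a 1.8-fold higher number from compound 1 to compound 2 (0.26 log units; within the scatter) as the only guide. The expected outcome in this assay is a 1.3-fold lower number from compound 2 to compound 4 (0.12 log units; within the scatter) and so no step beyond the scatter. The estimated value for compound 4 is 55000 nM with an expected range (from 24000 nM to 110000 nM).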

Compound 4, half-maximal inhibitory concentration: 23700 nM
Beside the measured number, compound 4's estimate is 2.3-fold (0.37 log units) above it, and the stated range ends above it.
By their numbers in this assay, from the lowest: compound 3; then compounds 4, 1 and 2 (each within the scatter of the next, the first and the last beyond it).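

Among these compounds, at the saturated chain carbon bound to an amide-type nitrogen in a ring, the choice of aryl group does move the number in this assay: naphthalen-2-yl in place of 4-phenylphenyl gives (a 3.1-fold lower number from compound 2 to compound 4 (0.49 log units; beyond the scatter)), the only step at this place beyond the scatter. Naphthalen-2-yl in place of 4-fluorophenyl gives (a 1.7-fold lower number from compound 1 to compound 4 (0.22 log units; within the scatter)), so these two groups stand level here. Nothing available explains the gap between naphthalen-2-yl and 4-phenylphenyl.

From the compounds shown here alone, it remains open how an amine or a carboxylic acid would read at this place. Going by these compounds, whether naphthalen-2-yl gives a similar step alongside the other substitution pattern of compound 3 also remains open.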